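The source may hold more compounds than are shown below. What is called first, only, known or untested is meant among the compounds shown, and "the series" means these compounds.

Compound 1 `CCOc1ccccc1-c1nnc(SCCn2c([N+](=O)[O-])cnc2C)o1` - 9800 nM
Compound 2 `Cc1ncc([N+](=O)[O-])n1CCSc1nnc(-c2ccccc2F)o1` - 3700 nM

In a functional assay on HepG2 cells (Homo sapiens) for cytotoxicity, read by MTT assay, with a stated time of 48 h (a lower number here means a stronger inhibitor, a higher number a weaker inhibitor), compound 2 holds the lower of the two numbers, 3700 nM, with compound 1 above it. Within the data shown here, compound 3 `Cc1ncc([N+](=O)[O-])n1CCSc1nnc(-c2ccco2)o1` has no value so far. Its difference from compound 2 is furan-2-yl in place of 2-fluorophenyl on an aromatic carbon, with furan-2-yl in place of 2-fluorophenyl on an aromatic carbon. Among the measured compounds shown here, only one measured step bears on this, and only loosely. That step, a 2.6-fold lower number from compound 1 to compound 2 (0.42 log units; beyond the scatter), was modest and put fluoro in place of ethoxy on an aromatic carbon. For the measured compounds named here, no measured step exchanges the whole 2-fluorophenyl group, so the direction is uncertain. A step of similar modest size in this assay is expected, leaning towards a higher number. For compound 3 the estimate is 5500 nM, with an expected range from 1900 nM to 16000 nM. This estimate means a 1.5-fold higher number from compound 2 to compound 3 (0.17 log units; within the scatter).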

Compound 3, half-maximal inhibitory concentration: 22600 nM
Estimate against measurement, compound 3: 4.1-fold (0.61 log units) below; the whole stated range lies below it.
By their numbers in this assay, from the lowest: compound 2; then compound 1; then compound 3.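

Replacing the whole ring on this aromatic carbon of the shared core, rather than only a substituent on it, gave a clear change in this assay: 2-fluorophenyl giving way to furan-2-yl produced a 6.1-fold higher number from compound 2 to compound 3 (0.79 log units; beyond the scatter). The earlier compounds had varied only the group carried by the phenyl ring, whereas compound 3 now holds the highest number of the three, so among these compounds both phenyl-bearing members read lower than the furan-2-yl one. Nothing measured here accounts for this difference.

Furan-2-yl is the only five-membered ring shown at this position, and it remains open whether other such rings, thiophene for example, would read like it. From the compounds shown here alone, how an unsubstituted phenyl or a pyridine ring would read in this assay also remains open.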